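This account rests on a few compounds, and the source may have more. Where it says the series, first, only, none or still open, it means among the compounds named here.

The measured compounds are:

compound 1, `CC1(/C=C/c2ccccc2O)C=CC(=O)O1`, which in a functional assay on UACC-62 cells (Homo sapiens) for inhibition, read by sulforhodamine B assay, with a stated time of 48 h (on this read-out higher numbers stand for weaker inhibition of growth and lower numbers for stronger inhibition of growth), gives 92500 nM;
compound 2, `CC1(/C=C/c2ccc(O)cc2)C=CC(=O)O1`, which in this assay gives 55300 nM;
compound 3, `COc1ccccc1/C=C/C1(C)C=CC(=O)O1`, which in this assay gives 31000 nM.

Compound 4, `COc1ccc(/C=C/C2(C)C=CC(=O)O2)cc1`, has not yet been measured in this assay. Compound 4 is derived from compound 2 by methyl in place of hydrogen on an oxygen on an aromatic ring. The same change has already been made once in this series, from compound 1 to compound 3, where it read (methyl in place of hydrogen on an oxygen on an aromatic ring), and there it gave a 3.0-fold lower number from compound 1 to compound 3 (0.47 log units; beyond the scatter). The two places are described in identical words, so the change from compound 2 to compound 4 is the same change, carried out on a different core. How the core of compound 2 differs from the core of compound 1 is not broken down here; the values of the two compounds lie within the usual scatter of each other, as do those of compound 2 and compound 3, so nothing can be said about an order among them.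

Within the data shown here, on this basis the step from compound 2 to compound 4 in this assay is expected to be of about the same size as the earlier one, that is a 2.9-fold lower number from compound 2 to compound 4 (0.46 log units; beyond the scatter), because the only precedent is a 3.0-fold lower number from compound 1 to compound 3 (0.47 log units; beyond the scatter) and the change is counted alike in both cases. Among the measured compounds shown here, since only a single precedent exists, and it was modest, the expectation is held loosely. Compound 4 is therefore estimated at 19000 nM, with a plausible range from 8000 nM to 50000 nM.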

Compound 4, concentration for total growth inhibition: 147000 nM
Compound 4: middle estimate off by 7.7-fold (0.89 log units), on the low side; the measured number lies above the stated range.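

In this assay, the change from hydroxy to methoxy gives a 2.7-fold higher number from compound 2 to compound 4 (0.42 log units; beyond the scatter), which on this read-out stands for weaker inhibition of growth, whereas the earlier step on the other core went the opposite way. Set side by side, the two steps show that in this series the effect of this change does not carry over from one core to the other, not even in its direction, and that the gap between them cannot be put down to ordinary variation between measurements: the same change on two cores in this assay, a 3.0-fold lower number (0.47 log units; beyond the scatter) from compound 1 to compound 3 and a 2.7-fold higher number (0.42 log units; beyond the scatter) from compound 2 to compound 4, 7.9-fold (0.90 log units) apart, beyond the scatter of two such steps. What this does not show is which feature of the two cores separates the outcomes, since the comparison rests on one pair of compounds for each core and both steps are modest, and it gives no rule for what the same change would do on any further core.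

The compounds shown leave open whether a longer chain on the same oxygen, such as an ethyl group, would follow the step seen on the core of compound 1 or the one seen on the core of compound 2. They also leave open how an amine or a fluorine atom in place of the hydroxy would read in this assay on either core.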